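This account rests on a few compounds, and the source may have more. Where it says the series, first, only, none or still open, it means among the compounds named here.

Measured in an assay on mitochondria (strain BALB/c) for inhibition of glycerol-3-phosphate acyltransferase 1, mitochondrial (Mus musculus), read by scintillation counting, with a stated time of 10 min; a higher number here means a weaker inhibitor, a lower number a stronger inhibitor:
compound 1 `CCCCCCCCS(=O)(=O)Nc1ccc(-c2cccc(Cl)c2)cc1C(=O)O`, 8900 nM
compound 2 `CCCCCCCCS(=O)(=O)Nc1ccc(-c2ccc(O)cc2)cc1C(=O)O`, 47300 nM

Compound 2 stands at the higher of the two numbers, with compound 1 at a 5.3-fold higher number from compound 1 to compound 2 (0.73 log units; beyond the scatter). Compound 3 `CCCCCCCCS(=O)(=O)Nc1ccc(CCc2ccccc2)cc1C(=O)O` is not yet measured; it differs from compound 2 by phenethyl in place of 4-hydroxyphenyl on an aromatic carbon. Among the measured compounds shown here, the only step that bears on it, a 5.3-fold higher number from compound 1 to compound 2 (0.73 log units; beyond the scatter), shows that the 4-hydroxyphenyl group sits at the weak end of the two aryl groups tried, so replacing it is expected to bring the number back down in this assay, by a modest margin. For compound 3 the estimate is 15000 nM, range 5000 nM to 45000 nM, meaning an expected step of a 3.2-fold lower number from compound 2 to compound 3 (0.50 log units; beyond the scatter).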

Compound 3, half-maximal inhibitory concentration: 37500 nM
Compound 3: the middle estimate sits 2.5-fold (0.40 log units) below what was measured; measured number inside the range.
By their numbers in this assay, from the lowest: compound 1; then compounds 3 and 2 (each within the scatter of the next).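

At this position on the shared core, in this assay, phenethyl and 4-hydroxyphenyl cannot be told apart (a 1.3-fold lower number from compound 2 to compound 3 (0.10 log units; within the scatter)), even though the hydrogen-bond donor and acceptor of 4-hydroxyphenyl are absent from phenethyl. Exchanging 3-chlorophenyl for phenethyl gives a clear loss (a 4.2-fold higher number from compound 1 to compound 3 (0.62 log units; beyond the scatter)), so 3-chlorophenyl remains the strongest of the three groups here. No supporting evidence is available to explain these results.

Open questions are how an unsubstituted phenyl, a 4-chlorophenyl or a benzyl group would compare at this position, and whether a shorter chain than octyl would preserve this order.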